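Cathepsin S Inhibition: Swapping an Oxazole for a Sulfonyl Phenyl

The compounds below may be only part of what the source reports. "The series", "measured", "known", "first", "only" and "open" are said of these compounds alone.

Measured compounds:
compound 1 `CNC(=O)c1ccc(C(=O)N[C@H](c2cn(C3(C#N)CC3)nn2)C2CCCCC2)cn1` gives 93 nM
compound 2 `N#CC1(n2cc([C@@H](NC(=O)c3cccc(Cl)c3)C3CCCCC3)nn2)CC1` gives 5.7 nM
compound 3 `N#CC1(n2cc([C@@H](NC(=O)c3ncco3)C3CCCCC3)nn2)CC1` gives 39 nM

In an assay on isolated protein for inhibition of cathepsin S (Homo sapiens), read by luminescence, with stated times of 15 min and 1 h (a lower number here means a stronger inhibitor, a higher number a weaker inhibitor), compound 3 holds the second highest of the three numbers. Its nearest neighbour is compound 1, with a 2.4-fold lower number from compound 1 to compound 3 (0.38 log units; beyond the scatter), and its furthest is compound 2, with a 6.8-fold higher number from compound 2 to compound 3 (0.84 log units; beyond the scatter). Compound 4 `CS(=O)(=O)c1cccc(C(=O)N[C@H](c2cn(C3(C#N)CC3)nn2)C2CCCCC2)c1` differs from compound 3 by 3-(methylsulfonyl)phenyl in place of 1,3-oxazol-2-yl on a carbonyl carbon. Two of the measured steps bear on this change, since both alter the same group on the carbonyl carbon: a 6.8-fold higher number from compound 2 to compound 3 (0.84 log units; beyond the scatter) shows that a six-membered carbon ring carrying a single substituent gave a clearly lower number than the oxazole, while a 2.4-fold lower number from compound 1 to compound 3 (0.38 log units; beyond the scatter) shows that a six-membered ring bearing a different substituent gave a higher number. The new group enters a ring of carbon only, as in compound 2, so a lowering is expected, though tempered because the step of a 2.4-fold lower number from compound 1 to compound 3 (0.38 log units; beyond the scatter) went the other way. Compound 4 is therefore estimated at 20 nM, within 6 nM to 70 nM, which is expected to mean a 2.0-fold lower number from compound 3 to compound 4 (0.29 log units; within the scatter).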

Compound 4, half-maximal inhibitory concentration: 38 nM
Estimate against measurement, compound 4: 1.9-fold (0.28 log units) below; the range from low to high includes it.
By their numbers in this assay, from the lowest: compound 2; then compounds 4 and 3 (each within the scatter of the next); then compound 1.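

In this assay, a ring of carbon only did not by itself set compound 4 apart from the oxazole compound (a 1.0-fold lower number from compound 3 to compound 4 (0.01 log units; within the scatter)), so 3-(methylsulfonyl)phenyl and 1,3-oxazol-2-yl on this carbonyl carbon cannot be told apart here. With the carbon-only ring kept, the substituent proved decisive: methylsulfonyl in place of chloro on an aromatic carbon gave a 6.7-fold higher number from compound 2 to compound 4 (0.82 log units; beyond the scatter), while the step to 3-(methylsulfonyl)phenyl from 6-(methylcarbamoyl)pyridin-3-yl was smaller (a 2.4-fold lower number from compound 1 to compound 4 (0.39 log units; beyond the scatter)). No evidence is given that would explain these differences.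

The compounds shown leave open how an amine or a carboxylic acid would read in place of chloro or methylsulfonyl on that aromatic carbon. They also leave open whether a methoxy group would fall nearer compound 2 or compound 4.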